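A few compounds are considered here, and "the series" means these few. Any claim that something is new, unique, unknown or untested is made for them only; others in the source may bear on it.

Measured compounds:
compound 1, `CC/C(=C(/c1ccc(/C=C/C(=O)O)cc1)c1cc2ccccc2[nH]1)c1ccccc1Cl`: 42 nM
compound 2, `CC/C(=C(/c1ccc(/C=C/C(=O)O)cc1)c1cc2ccccc2[nH]1)c1ccccc1C(F)(F)F`: 8 nM
compound 3, `CC/C(=C(/c1ccc(/C=C/C(=O)O)cc1)c1cc2ccccc2[nH]1)c1ccc(Cl)cc1`: 343 nM

All three share one core and differ only in the aryl group on the double-bonded chain carbon bound to a double-bonded chain carbon and a saturated chain carbon. In a functional assay on MCF7 cells (Homo sapiens) for inhibition (a higher number here means a weaker inhibitor, a lower number a stronger inhibitor), compound 3 gives the highest of the three numbers, with compound 1 nearest and compound 2 furthest. Compound 4, `CC/C(=C(/c1ccc(/C=C/C(=O)O)cc1)c1cc2ccccc2[nH]1)c1cccc(Cl)c1Cl`, is not yet measured; it differs from compound 3 by 2,3-dichlorophenyl in place of 4-chlorophenyl on a double-bonded chain carbon bound to a double-bonded chain carbon and a saturated chain carbon. Within the data shown here, two measured steps bear on this change: an 8.2-fold higher number from compound 1 to compound 3 (0.91 log units; beyond the scatter) and a 43-fold higher number from compound 2 to compound 3 (1.63 log units; beyond the scatter). In both, the 4-chlorophenyl is the weaker end, and the 2-chlorophenyl of compound 1 or the 2-(trifluoromethyl)phenyl of compound 2 the stronger. Among the measured compounds shown here, the 2,3-dichlorophenyl of compound 4 resembles the 2-chlorophenyl of compound 1 most closely; the second chloro has no measured counterpart, so the 2-chlorophenyl is the guide. A modest drop is therefore expected, an 8.6-fold lower number from compound 3 to compound 4 (0.93 log units; beyond the scatter). For compound 4 in this assay the estimate is 40 nM, with a range of 12 nM to 130 nM.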

Compound 4, half-maximal inhibitory concentration: 898 nM
Beside the measured number, compound 4's estimate is 22-fold (1.35 log units) below it, and the stated range ends below it.
By their numbers in this assay, from the lowest: compound 2; then compound 1; then compound 3; then compound 4.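

In this assay, the added chloro reverses the picture around the 2-chlorophenyl group: a 21-fold higher number from compound 1 to compound 4 (1.33 log units; beyond the scatter), so chloro in place of hydrogen on an aromatic carbon is far from neutral in this aryl group. The 2,3-dichlorophenyl group even falls behind the 4-chlorophenyl group, with a 2.6-fold higher number from compound 3 to compound 4 (0.42 log units; beyond the scatter), and well behind the 2-(trifluoromethyl)phenyl group, with a 110-fold higher number from compound 2 to compound 4 (2.05 log units; beyond the scatter), so the 2-chlorophenyl pattern alone does not secure a low number once the ring carries a second chloro. Nothing measured here explains this loss.

From the compounds shown here alone, it remains open whether the loss follows from chloro specifically or from any added group at that ring carbon. A 3-chlorophenyl or 3-methylphenyl group in the same place would help separate these readings, and a 2-methyl-3-chlorophenyl group would test the pairing further.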